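Chain extension from compound 2 to compound 3

A few compounds are considered here, and "the series" means these few. Any claim that something is new, unique, unknown or untested is made for them only; others in the source may bear on it.

Values so far in a functional assay on RAW264.7 cells (Mus musculus) for inhibition, read by ELISA, with a stated time of 24 h (on this read-out lower numbers stand for an effect already at smaller amounts and higher numbers for an effect only at larger amounts of compound), are these:
compound 1 `CC/C=C\C[C@H]1C(=O)C=C[C@H]1CC(=O)OCCCCC` (25000 nM)
compound 2 `CC/C=C\C[C@H]1C(=O)C=C[C@H]1CC(=O)OCCOC` (27000 nM)

On these two numbers, compound 2 (27000 nM) stands level with compound 1 (25000 nM) within the scatter, so no order can be drawn between them. Compound 3 `CC/C=C\C[C@H]1C(=O)C=C[C@H]1CC(=O)OCCOCCOCCOC` is the next to be read. Its difference from compound 2 ((2-methoxyethoxy)methyl in place of hydrogen on a saturated chain carbon bound to an oxygen on a saturated carbon) is (2-methoxyethoxy)methyl in place of hydrogen on a saturated chain carbon bound to an oxygen on a saturated carbon. Cut one bond further out, the same difference reads methoxy to 2-(2-methoxyethoxy)ethoxy.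

Among the measured compounds shown here, the one measured step that bears on this (a 1.1-fold higher number from compound 1 to compound 2 (0.03 log units; within the scatter)) exchanges methoxy for propyl and lies within the scatter. For the measured compounds named here, no measured compound carries a chain of the length found in compound 3, so this is a thin guide. On that evidence, no step beyond the scatter and no particular direction is expected in this assay for this change. The step expected from the estimate (a 1.0-fold lower number from compound 2 to compound 3 (0.02 log units; within the scatter)) stays within that scatter. For compound 3 the estimated value is 26000 nM with an expected range from 12000 nM to 50000 nM in this series.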

Compound 3, half-maximal effective concentration: 35000 nM
The estimate for compound 3 lay 1.3-fold (0.13 log units) below the measured number; measured number inside the range.
By their numbers in this assay, from the lowest: compounds 1, 2 and 3 (each within the scatter of the next).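

In this assay, (2-methoxyethoxy)methyl in place of hydrogen on a saturated chain carbon bound to an oxygen on a saturated carbon gives a 1.3-fold higher number from compound 2 to compound 3 (0.11 log units; within the scatter) and so shows that this place accepts a group of 6 heavy atoms, with 2 hydrogen-bond acceptors, without a step beyond the scatter. The larger exchange, which puts 2-(2-methoxyethoxy)ethoxy where propyl stood, gives a 1.4-fold higher number from compound 1 to compound 3 (0.15 log units; within the scatter) and likewise stays within the scatter, whereas the earlier pair covered only the exchange of methoxy for propyl. No measurement at hand accounts for these level readings.

From the compounds shown here alone, whether an amine or a carboxylic acid at the end of the chain, or a phenyl ring in place of the chain end, would give a step beyond the scatter remains open. Also open, going by these compounds, is whether any group at this place can shift the number in this assay at all, since compounds 1, 2 and 3 all read level.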